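Compound 3 and the limit of compound 2

The source may hold more compounds than are shown below. What is called first, only, known or untested is meant among the compounds shown, and "the series" means these compounds.

Measured compounds:
Compound 1 `c1ccc(-c2cccc(Oc3cccc(Cn4ccnc4)c3)c2)cc1` | 34000 nM
Compound 2 `Cc1cc(C)cc(Oc2cccc(Cn3ccnc3)c2)c1` | > 100000 nM

In an ADME assay on NIH3T3 cells (Mus musculus) for cytotoxicity (a lower number here means that less compound is needed, a higher number that more compound is needed for the effect), compound 1 gives 34000 nM as a measured number. For compound 2 the entry > 100000 nM is a limit of the assay and not a number, so compound 2 has no exact position on the scale. Compound 3 `Cc1cccc(Oc2cccc(Cn3ccnc3)c2)c1` carries hydrogen in place of methyl on an aromatic carbon and is otherwise the same as compound 2. Among the measured compounds shown here, no measured pair shows the size of this change. In this assay no step beyond the scatter is therefore expected, and the result may again be only a limit. The expected change is an at least 1.1-fold lower number from compound 2 to compound 3 (0.04 log units; that floor lies within the scatter) and remains an estimate. For compound 3 the expected value is 90000 nM with an estimated range from 40000 nM to 200000 nM in this assay.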

Compound 3, half-maximal effective concentration: 78700 nM
For compound 3 the middle estimate is 1.1-fold (0.06 log units) above the measured one; low and high end bracket the measured number.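

Among the compounds shown here, with compound 3, this aromatic carbon has a measured number for both a methyl and a phenyl group in this assay, and the exchange of one for the other can be sized for the first time as a 2.3-fold higher number from compound 1 to compound 3 (0.36 log units; beyond the scatter) and is thus larger than the usual scatter. Taking away the second methyl can be read only as a floor, an at least 1.2-fold lower number from compound 2 to compound 3 (0.10 log units; that floor lies within the scatter) and the true size of the step may be larger. The value of compound 2 is a limit of the assay and not a number, which is why only a floor can be given: the limit of > 100000 nM in this assay, at which 1 of the 3 values shown sits.

The compounds shown leave open how a group other than hydrogen, methyl or phenyl at this carbon would read, for example a methoxy group, a chlorine atom or a carboxylic acid. They also leave open whether the step from phenyl to methyl would have the same size elsewhere on the shared core.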